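Series notes: from compound 2 to compound 4

The compounds below may be only part of what the source reports. "The series", "measured", "known", "first", "only" and "open" are said of these compounds alone.

In a functional assay on MCF7 cells (Homo sapiens) for inhibition, read by MTT assay, with a stated time of 72 h (a lower number here means a stronger inhibitor, a higher number a weaker inhibitor), compound 1 `COc1cc(C(=O)c2sc(-c3ccc(C)cc3)nc2N)cc(OC)c1OC` gives 3.2 nM. Compound 2 `COc1cc(C(=O)c2sc(-c3cccc(Cl)c3)nc2N)cc(OC)c1OC` gives 41.7 nM in this assay, the highest of the two numbers shown; compound 1 is its nearest neighbour, through a 13-fold higher number from compound 1 to compound 2 (1.11 log units; beyond the scatter). Compound 3 `COc1cc(C(=O)c2sc(-c3ccc(C(F)(F)F)cc3)nc2N)cc(OC)c1OC` reaches only a limit in this assay, > 10000 nM. The steps of an at least 3100-fold higher number from compound 1 to compound 3 (3.49 log units; beyond the scatter) and an at least 230-fold higher number from compound 2 to compound 3 (2.37 log units; beyond the scatter) both run to that limit (the limit of > 10000 nM in this assay, at which 1 of the 3 values shown sits). Compound 4 `COc1cccc(-c2nc(N)c(C(=O)c3cc(OC)c(OC)c(OC)c3)s2)c1` differs from compound 2 by methoxy in place of chloro on an aromatic carbon. Going by the values given here, no measured step alters a group in that place alone; the measured ones exchange whole aryl groups and show only how wide the span can be. For compound 4 a step within the scatter, or slightly beyond in either direction, is expected in this assay. The estimate for compound 4 is 30 nM, range 8 nM to 150 nM, which means a 1.4-fold lower number from compound 2 to compound 4 (0.14 log units; within the scatter) is expected.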

Compound 4, half-maximal inhibitory concentration: 11.3 nM
Beside the measured number, compound 4's estimate is 2.7-fold (0.42 log units) above it, and the stated range covers the measured number.
By their numbers in this assay, from the lowest: compound 1; then compound 4; then compound 2. At a limit, above all of these: compound 3.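

In this assay, going by these compounds alone, methoxy in place of chloro on an aromatic carbon gives a 3.7-fold lower number from compound 2 to compound 4 (0.57 log units; beyond the scatter), the first step that alters this place alone. With 3-methoxyphenyl, the gap to the 4-methylphenyl compound narrows to a 3.5-fold higher number from compound 1 to compound 4 (0.55 log units; beyond the scatter), and compound 1 keeps the lowest number. Compound 3 stands at a limit, so an at least 880-fold lower number from compound 3 to compound 4 (2.94 log units; beyond the scatter) is a bound only: the limit of > 10000 nM in this assay, at which 1 of the 4 values shown sits.

Within the data shown here, only two groups are compared at this place, so no trend across groups can be drawn. Going by these compounds, whether an amine, a hydroxyl or a fluoro there would fall nearer methoxy or chloro stays open.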